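Chalcone triazole ethers: methoxy gives way to nitro

The compounds below may be only part of what the source reports. "The series", "measured", "known", "first", "only" and "open" are said of these compounds alone.

Compound 1 `O=C(/C=C/c1ccc(OCc2cn(Cc3ccccc3)nn2)cc1)c1ccc(Br)cc1` gives 44% in a functional assay on MIA PaCa-2 cells (Homo sapiens) for inhibition, read by MTT assay, with a stated time of 48 h, tested at 10 uM; on this read-out higher numbers stand for more inhibition of growth at the one concentration tested and lower numbers for less inhibition of growth.
Compound 2 `COc1ccc(C(=O)/C=C/c2ccc(OCc3cn(Cc4ccccc4)nn3)cc2)cc1` gives 68% in this assay.

Within the data shown here, compound 2 holds the higher of these two numbers; the single known step, a number 24 percentage points higher from compound 1 to compound 2 (beyond the scatter), separates it from compound 1. Compound 3 `O=C(/C=C/c1ccc(OCc2cn(Cc3ccccc3)nn2)cc1)c1ccc([N+](=O)[O-])cc1` differs from compound 2 by nitro in place of methoxy on an aromatic carbon. Among the measured compounds shown here, no measured step exchanges a methoxy for a nitro group, so the bromo-to-methoxy step does not bear directly on this change. Compound 3 is therefore expected to land near or somewhat below compound 2, the expected step being a number 16 percentage points lower from compound 2 to compound 3 (beyond the scatter). The estimate for compound 3 is 52%, between 28% and 76%.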

Compound 3, percent growth inhibition at one concentration: "not active" (no number reported)
Compound 3: no number reported; no gap can be computed for the estimate.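

Among these compounds, compound 3 is reported as not active in this assay, without a number, so no step from compound 2 to compound 3 can be read. Nothing shown explains this result. The compounds shown leave open how large the difference between compound 2 and compound 3 is.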